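A Phenyl Substituent Swap on an Adenosine Ligand Core

The source may hold more compounds than are shown below. What is called first, only, known or untested is meant among the compounds shown, and "the series" means these compounds.

Measured compounds:
Compound 1: `Cn1c(-c2ccc(F)cc2)nc2c(NC3CCCC3)ncnc21`, 6.2 nM
Compound 2: `Cn1c(-c2ccccc2)nc2c(NC3CCOC3)ncnc21`, 8 nM

Both compounds were tested in an assay on CHO cells for displacement of a labelled ligand from adenosine receptor A1 (Homo sapiens), read by scintillation counting, with a stated time of 3 h; on this read-out lower numbers stand for stronger inhibition and higher numbers for weaker inhibition. Compound 1 gives 6.2 nM, and compound 2 gives 8 nM. On the numbers shown compound 1 stands alongside compound 2; the two values lie within the scatter of each other, so neither can be set apart. Among the compounds with values here, the two compounds differ in more than one place, so no single step between them can be read.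

Compound 3, `Cc1cccc(-c2nc3c(NC4CCCC4)ncnc3n2C)c1`, is not yet measured. It differs from compound 1 in one place: 3-methylphenyl in place of 4-fluorophenyl on an aromatic carbon. Within the data shown here, with no comparable step among the measured compounds, the size of this change is uncertain; a modest step is expected, no larger than the scatter or a little weaker. The step from compound 1 to compound 3 is estimated as a 1.5-fold higher number from compound 1 to compound 3 (0.16 log units; within the scatter). Compound 3 is expected to give 9 nM, in a range from 3 nM to 30 nM.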

Compound 3, inhibition constant: 6.2 nM
Estimate against measurement, compound 3: 1.5-fold (0.16 log units) above; the range from low to high includes it.
By their numbers in this assay, from the lowest: compounds 1, 3 and 2 (each within the scatter of the next).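

In this assay, within the data shown here, 3-methylphenyl in place of 4-fluorophenyl gives no change at the digits printed from compound 1 to compound 3 (within the scatter) and this is the first step in the set that can be read at a single place. On this aromatic carbon, one substituted phenyl can thus replace another with no change that stands out from the scatter, although the two groups carry their substituents at different ring positions and differ in fluorine against methyl. No measurement shown bears on why the two groups read alike.

From the compounds shown here alone, both groups are six-membered aromatic rings of carbon only, so it remains open whether a pyridine ring, a phenyl bearing a carboxylic acid or an amine, or a longer alkyl chain would be accepted at this position. Going by these compounds, it is also open whether the same swap would read alike on the core of compound 2.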